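Lengthening the Linker of Compound 3 by One Carbon

The source may report more compounds than this note shows. Statements on the series, on what has been measured and on what is new or still open speak of the compounds shown alone.

Three compounds were measured in a functional assay on A549 cells (Homo sapiens) for antiproliferative activity, read by MTT assay, with a stated time of 72 h; on this read-out lower numbers stand for stronger inhibition and higher numbers for weaker inhibition. Compound 1 `COc1cc2c(Oc3ccc(NC(=O)NN4C(=O)CSC4c4c(F)cccc4F)c(Cl)c3)ccnc2cc1OCCCN1CCCC1` gives 960 nM in this assay. Compound 2 `COc1cc2c(Oc3c(F)cc(NC(=O)NN4C(=O)C(C)(C)SC4c4c(F)cccc4F)cc3F)ccnc2cc1OCCCN1CCCC1` gives 1450 nM in this assay. Compound 3 `CCN1CCN(CCCOc2cc3nccc(Oc4c(F)cc(NC(=O)NN5C(=O)CSC5c5c(F)cccc5F)cc4F)c3cc2OC)CC1` gives 350 nM in this assay, the lowest of the three numbers; its gaps to compound 1 and to compound 2 both lie beyond the usual scatter, so compound 3 is the most potent compound measured here.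

Compound 4 `CCN1CCN(CCCCOc2cc3nccc(Oc4c(F)cc(NC(=O)NN5C(=O)CSC5c5c(F)cccc5F)cc4F)c3cc2OC)CC1` is not yet measured. It differs from compound 3 in one place: (4-ethylpiperazin-1-yl)methyl in place of 4-ethylpiperazin-1-yl on a saturated chain carbon, three bonds along the chain from an oxygen on an aromatic ring. Within the data shown here, no pair among the measured compounds shows a step of this kind, so there is nothing in the data to anchor a direction. The chain grows by a single carbon while the ring at its end and its donors and acceptors stay unchanged; a step of this size is expected to fall within the scatter, perhaps slightly toward a higher number. Compound 4 is therefore estimated at 450 nM, with a range from 200 nM to 1000 nM. This estimate means an expected step of a 1.3-fold higher number from compound 3 to compound 4 (0.11 log units; within the scatter).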

Compound 4, half-maximal inhibitory concentration: 1390 nM
The estimate for compound 4 lay 3.1-fold (0.49 log units) below the measured number, outside the stated range (above it).
By their numbers in this assay, from the lowest: compound 3; then compounds 1, 4 and 2 (each within the scatter of the next).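

In this assay, among these compounds, the added chain carbon gives the first step at this position that can be read on its own: a 4.0-fold higher number from compound 3 to compound 4 (0.60 log units; beyond the scatter). The earlier compounds shown here differ from one another in more than one place and could not isolate this change, whereas this pair shows that going from 3-(4-ethylpiperazin-1-yl)propyl to 4-(4-ethylpiperazin-1-yl)butyl matters even though the ring at the chain end and the counted donors and acceptors stay the same. Nothing available explains this step.

As far as these compounds go, it remains open whether a shorter 2-(4-ethylpiperazin-1-yl)ethyl chain would give a lower or a higher number than compound 3, so this one pair fixes no best chain length. Also open, from the compounds shown here alone, is whether the same lengthening would have a similar effect with a morpholine at the chain end.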